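Sulfonyl to dimethylamino on the benzoyl of compound 2

The compounds below may be only part of what the source reports. "The series", "measured", "known", "first", "only" and "open" are said of these compounds alone.

Of the compounds shown here, two have numbers so far. Compound 1 `CNC(=O)c1cccc(S(=O)(=O)Oc2ccc(-c3cncn3C3CCN(C(=O)c4ccc(N(C)C)cc4)CC3)cc2)c1` gives 22 nM in an assay on THP-1 cells for antagonist activity at P2X purinoceptor 7 (Homo sapiens), read by ELISA, with a stated time of 30 min; on this read-out higher numbers stand for weaker inhibition and lower numbers for stronger inhibition. Compound 2 `CS(=O)(=O)c1ccc(C(=O)N2CCN(c3cc(=O)[nH]c(=O)n3Cc3ccc(OS(=O)(=O)c4cccc5cnccc45)cc3)CC2)cc1` gives 50 nM in this assay, the higher of the two numbers, and the gap between compound 1 and compound 2 lies beyond the scatter. Going by the values given here, the two compounds differ in several places at once, so no single step is defined between them; their values show only that compound 2 is the weaker of the pair.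

The next compound, compound 3 `CN(C)c1ccc(C(=O)N2CCN(c3cc(=O)[nH]c(=O)n3Cc3ccc(OS(=O)(=O)c4cccc5cnccc45)cc3)CC2)cc1`, changes a single place on compound 2: dimethylamino in place of methylsulfonyl on an aromatic carbon. Compound 3 thereby carries the same (4-(dimethylamino)phenyl)carbonyl that is present in compound 1, but the rest of the core is that of compound 2, so the value of compound 1 cannot be read across directly. For the step from compound 2 to compound 3 a modest movement toward a lower number is expected, a 1.4-fold lower number from compound 2 to compound 3 (0.15 log units; within the scatter), with the possibility that it stays within the scatter. Compound 3 is estimated at 35 nM in this assay, within a range of 12 nM to 110 nM.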

Compound 3, half-maximal inhibitory concentration: 1.33 nM
Estimate against measurement, compound 3: 26-fold (1.42 log units) above, and the stated range ends above it.
By their numbers in this assay, from the lowest: compound 3; then compound 1; then compound 2.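

In this assay, dimethylamino in place of methylsulfonyl on an aromatic carbon, para to a large group, gives a 38-fold lower number from compound 2 to compound 3 (1.58 log units; beyond the scatter), a large step well beyond the scatter. Going by these compounds alone, this is the first change that can be read at a single place, and it shows that the group at this position of the six-membered aromatic ring can by itself strongly shift the inhibition read-out while the shared core stays unchanged. Nothing at hand bears on the reason for the size of this step.

With a single pair at this position, the step cannot be divided between the departure of methylsulfonyl and the arrival of dimethylamino; a plain hydrogen, a methoxy group or a primary amine at the same place would help separate the two. Also open, going by these compounds, is whether the step carries over to the core of compound 1, which could be tested by placing methylsulfonyl instead of its dimethylamino on the same ring.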